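The source may report more compounds than this note shows. Statements on the series, on what has been measured and on what is new or still open speak of the compounds shown alone.

Working notes on the series, followed in an ADME assay on microsomes from liver (Homo sapiens) for metabolic stability, read by LC-MS, using NADPH, with stated times of 5 min and 30 min, tested at 1 uM; on this read-out higher numbers stand for fast clearance and lower numbers for slow clearance. Compound 1 (`Cc1nc(CO)ccc1-c1cnc(NCc2c(F)ccc3c2CCO3)c2cn[nH]c(=O)c12`) gives 11 mL.min-1.g-1, compound 2 (`Cc1ncc(-c2cnc(NCc3c(F)ccc4c3CCO4)c3cn[nH]c(=O)c23)n1C`) gives 10 mL.min-1.g-1, and compound 3 (`CN(C)C(=O)c1cc(-c2cnc(NCc3c(F)ccc4c3CCO4)c3cn[nH]c(=O)c23)n(C)n1`) gives 21 mL.min-1.g-1, the highest of the three numbers. The step of a 1.1-fold lower number from compound 1 to compound 2 (0.04 log units; within the scatter) lies within the scatter, and so does a 1.9-fold higher number from compound 1 to compound 3 (0.28 log units; within the scatter). Only a 2.1-fold higher number from compound 2 to compound 3 (0.32 log units; beyond the scatter) lies beyond it, and modestly.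

Compound 4 (`CNC(=O)c1ncc(-c2cnc(NCc3c(F)ccc4c3CCO4)c3cn[nH]c(=O)c23)n1C`) has not yet been measured. Its difference from compound 3 is 1-methyl-2-(methylcarbamoyl)-1H-imidazol-5-yl in place of 3-(dimethylcarbamoyl)-1-methyl-1H-pyrazol-5-yl on an aromatic carbon. In words, 1-methyl-2-(methylcarbamoyl)-1H-imidazol-5-yl stands in place of 3-(dimethylcarbamoyl)-1-methyl-1H-pyrazol-5-yl on an aromatic carbon.

Among the compounds with values here, no measured step makes this exact change. The nearest evidence is the step between the two compounds that each resemble compound 4 in part. The entering group has an imidazol-5-yl ring like that of compound 2, at 10 mL.min-1.g-1, and a carbamoyl group like that of compound 3, at 21 mL.min-1.g-1. A value inside that narrow span is therefore expected, so only a small decrease is anticipated, with no firm change beyond the scatter. The expected step is a 1.5-fold lower number from compound 3 to compound 4 (0.18 log units; within the scatter). For compound 4 the estimated value is 14 mL.min-1.g-1, with an expected range from 7 mL.min-1.g-1 to 28 mL.min-1.g-1.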

Compound 4, intrinsic clearance in microsomes: 24 mL.min-1.g-1
Compound 4: middle estimate off by 1.7-fold (0.23 log units), on the low side, within the range that was stated.
By their numbers in this assay, from the lowest: compounds 2, 1, 3 and 4 (each within the scatter of the next, the first and the last beyond it).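

In this assay, within the data shown here, methylcarbamoyl in place of methyl on an aromatic carbon is the first change at this position confined to one small group, and it gives a 2.4-fold higher number from compound 2 to compound 4 (0.38 log units; beyond the scatter) on the same five-membered ring. The other new comparison swaps the whole group, and a 1.1-fold higher number from compound 3 to compound 4 (0.06 log units; within the scatter) shows that 1-methyl-2-(methylcarbamoyl)-1H-imidazol-5-yl and 3-(dimethylcarbamoyl)-1-methyl-1H-pyrazol-5-yl cannot be told apart here, although only the former carries the amide hydrogen. Against 6-(hydroxymethyl)-2-methylpyridin-3-yl, the result is a 2.2-fold higher number from compound 1 to compound 4 (0.34 log units; beyond the scatter) and so passes the scatter, whereas a 1.9-fold higher number from compound 1 to compound 3 (0.28 log units; within the scatter) did not, which means the two carbamoyl-bearing compounds do not separate in the same way from compound 1.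

Nothing shown here bears on the cause of these steps. As far as these compounds go, it remains open whether the step from methyl depends on the methylcarbamoyl group itself or would also appear with a primary carboxamide, a carboxylic acid or a nitrile at the same place on the ring, and whether a dimethylcarbamoyl group there would give a different reading from methylcarbamoyl.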